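The source may hold more compounds than are shown below. What is called first, only, known or untested is meant among the compounds shown, and "the series" means these compounds.

Among the compounds with values here, compound 1 `Cc1ccc(/C=N/NC(=O)c2oc3nc(-c4ccccc4)cc(C(F)(F)F)c3c2N)cc1` is the most potent of the three measured members of this small set: in a functional assay on HepG2 cells (Homo sapiens) for antiproliferative activity, read by MTT assay (on this read-out lower numbers stand for stronger inhibition and higher numbers for weaker inhibition), compound 1 gives 8900 nM. Compound 2 `CCCNC(=O)c1oc2nc(-c3ccccc3)cc(C(F)(F)F)c2c1N` differs from it only at the amide, where the change is a group of 3 heavy atoms (3 carbon; no ring) in place of a group of 9 heavy atoms (8 carbon, 1 nitrogen; one six-membered aromatic ring of carbon only), on an amide-type nitrogen, and in this assay compound 2 gives 37400 nM, which amounts to a 4.2-fold higher number from compound 1 to compound 2 (0.62 log units; beyond the scatter). Compound 3 `Cc1ccc(/C=N/NC(=O)c2oc3nc(-c4cccs4)cc(C(F)(F)F)c3c2N)cc1` keeps the hydrazone arm of compound 1 but carries a different core; the two cores differ by thiophen-2-yl in place of phenyl on an aromatic carbon. In this assay compound 3 gives 19800 nM, a move of a 2.2-fold higher number from compound 1 to compound 3 (0.35 log units; beyond the scatter).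

Compound 4 `CCCNC(=O)c1oc2nc(-c3cccs3)cc(C(F)(F)F)c2c1N` has not been measured. It stands to compound 3 as compound 2 stands to compound 1: the change is a group of 3 heavy atoms (3 carbon; no ring) in place of a group of 9 heavy atoms (8 carbon, 1 nitrogen; one six-membered aromatic ring of carbon only), on an amide-type nitrogen, and the surroundings of the place are the same as in the change from compound 1 to compound 2, so this is the same change, now made on the core of compound 3. The one earlier occurrence of that change weakened activity by a 4.2-fold higher number from compound 1 to compound 2 (0.62 log units; beyond the scatter). Because compound 3 already starts from 19800 nM, compound 4 is expected to move by about a 3.8-fold higher number from compound 3 to compound 4 (0.58 log units; beyond the scatter), on the assumption that the amide change behaves much as it did before; with a single precedent, the expectation is loose. Compound 4 is therefore estimated at 75000 nM, with a range from 30000 nM to 180000 nM.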

Compound 4, half-maximal inhibitory concentration: 17200 nM
Compound 4: middle estimate off by 4.4-fold (0.64 log units), on the high side; measured number outside the range, below it.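

On the core of compound 3, propyl in place of the hydrazone arm gives a 1.2-fold lower number from compound 3 to compound 4 (0.06 log units; within the scatter), so in this assay this change leaves no measurable mark there, while on the core of compound 1 it weakened activity, and the two steps do not agree: the same change on two cores in this assay, a 4.2-fold higher number (0.62 log units; beyond the scatter) from compound 1 to compound 2 and a 1.2-fold lower number (0.06 log units; within the scatter) from compound 3 to compound 4, 4.8-fold (0.68 log units) apart, beyond the scatter of two such steps

The exchange at the other place depends on its surroundings in the same way, for thiophen-2-yl in place of phenyl gives a 2.2-fold lower number from compound 2 to compound 4 (0.34 log units; beyond the scatter) when the amide carries propyl, the opposite direction to the step seen with the hydrazone arm: the same change on two cores in this assay, a 2.2-fold higher number (0.35 log units; beyond the scatter) from compound 1 to compound 3 and a 2.2-fold lower number (0.34 log units; beyond the scatter) from compound 2 to compound 4, 4.8-fold (0.68 log units) apart, beyond the scatter of two such steps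

The two places therefore do not act independently in these four compounds, and a step measured on one core cannot simply be added onto the other, but this single square of compounds does not show why they interact, nor which of the two cores shows the more usual behaviour.

The compounds shown leave open whether the same dependence would appear with a longer chain such as butyl, or with a basic amine, on the amide nitrogen. They also leave open whether a furan-2-yl group in place of phenyl would follow the thiophen-2-yl compounds or the phenyl compounds.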